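Chloro to bromo exchange in two related cores

The source may hold more compounds than are shown below. What is called first, only, known or untested is meant among the compounds shown, and "the series" means these compounds.

Measured in a functional assay on PC-3 cells (Homo sapiens) for inhibition, read by MTT assay, with a stated time of 72 h; a lower number here means a stronger inhibitor, a higher number a weaker inhibitor:
compound 1 `O=C(CSc1nc(Nc2ccccc2)c2ccccc2n1)Nc1ccccc1Cl` gives 14600 nM
compound 2 `O=C(CSc1nc(Nc2ccccc2)c2ccccc2n1)Nc1ccccc1Br` gives 19800 nM
compound 3 `C=CC(=O)Nc1cccc(NC(=O)CSc2nc(Nc3ccc(Cl)cc3)c3ccccc3n2)c1` gives 10800 nM

Compound 4 `C=CC(=O)Nc1cccc(NC(=O)CSc2nc(Nc3ccc(Br)cc3)c3ccccc3n2)c1` is not yet measured. The three measured values lie within the scatter of one another. The change from compound 1 to compound 2 is bromo in place of chloro on an aromatic carbon, and it made a 1.4-fold higher number from compound 1 to compound 2 (0.13 log units; within the scatter). The change from compound 3 to compound 4 is bromo in place of chloro on an aromatic carbon. This is the same kind of change, but the place differs: in compound 1 the halogen sits ortho to a large group, in compound 3 para to a large group. The difference between the two cores is not broken down here. For compound 4 a step of a 1.3-fold higher number from compound 3 to compound 4 (0.11 log units; within the scatter) is expected. Going by the values given here, this expectation rests on the one measured example, a 1.4-fold higher number from compound 1 to compound 2 (0.13 log units; within the scatter), with the reservation that only one pair is available and the place around the halogen is not the same. The estimated value for compound 4 in this assay is 14000 nM, with a range from 7000 nM to 28000 nM.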

Compound 4, half-maximal inhibitory concentration: 12400 nM
Beside the measured number, compound 4's estimate is 1.1-fold (0.05 log units) above it; low and high end bracket the measured number.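

In this assay, bromo in place of chloro, para to a large group, gives a 1.1-fold higher number from compound 3 to compound 4 (0.06 log units; within the scatter). Set beside the earlier pair, the step reads alike on both cores: the same change on two cores in this assay, a 1.4-fold higher number (0.13 log units; within the scatter) from compound 1 to compound 2 and a 1.1-fold higher number (0.06 log units; within the scatter) from compound 3 to compound 4, 1.2-fold (0.07 log units) apart, within the scatter of two such steps. This shows that the exchange stayed within the scatter in both available pairs, but two pairs do not establish a general rule for other cores, and with neither step beyond the scatter they show no measurable effect of the exchange.

Still open, from the compounds shown here alone, is whether an amine or a carboxylic acid in place of the halogen would move the number beyond the scatter. The compounds shown also do not separate the contributions of the several places in which the two cores differ.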